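The source may hold more compounds than are shown below. What is called first, only, known or untested is meant among the compounds shown, and "the series" means these compounds.

Working notes on the series. Compound 1 `CCCC(CCC)Nc1ncnc2c1ncn2C1O[C@H](CO)[C@@H](O)[C@H]1O` in an assay on cell membranes for binding affinity to adenosine receptor A1 (Cavia porcellus), read by radioligand binding (on this read-out higher numbers stand for weaker inhibition and lower numbers for stronger inhibition), gives 3.3 nM, the lowest of the three numbers shown, with compound 3 `CCCn1c(=O)c2nc([C@H]3CC4C=CC3C4)[nH]c2n(CCC)c1=O` at 3.4 nM within the scatter of it and compound 2 `CCCn1c(=O)c2nc(C(C)(C)CCC)[nH]c2n(CCC)c1=O` at 25 nM beyond. The one step shown, a 7.4-fold lower number from compound 2 to compound 3 (0.87 log units; beyond the scatter), lies on a core different from that of compound 1 and on an aromatic carbon, and it trades an acyclic group for a ring-bearing one.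

Compound 4 `CC(C)(C)CNc1ncnc2c1ncn2C1O[C@H](CO)[C@@H](O)[C@H]1O` differs from compound 1 by neopentyl in place of 1-propylbutyl on a nitrogen on an aromatic ring. For the measured compounds named here, no measured step touches this nitrogen or compares two acyclic groups of this kind, so the change stands without a direct precedent; the step from compound 2 to compound 3 shows only that the group at the variable position can shift this assay modestly. Within the scatter of the neighbouring numbers, compound 4 is expected to give 10 nM, in the range 2.5 nM to 40 nM. The estimated step of a 3.0-fold higher number from compound 1 to compound 4 (0.48 log units; beyond the scatter) is thus a modest rise, and a result within the scatter would not be surprising.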

Compound 4, inhibition constant: 17 nM
Compound 4: middle estimate off by 1.7-fold (0.23 log units), on the low side, and the stated range covers the measured number.
By their numbers in this assay, from the lowest: compounds 1 and 3 (each within the scatter of the next); then compounds 4 and 2 (each within the scatter of the next).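

On the core of compound 1, the group on this nitrogen moves the number in this assay: neopentyl in place of 1-propylbutyl gives a 5.2-fold higher number from compound 1 to compound 4 (0.71 log units; beyond the scatter). Neither group carries a ring, a hydrogen-bond donor, a hydrogen-bond acceptor or a net charge, so this modest step is seen with none of these counts changing. Nothing measured here bears on the cause of the step.

With only two groups shown on this nitrogen, the separate roles of chain length and branching remain open, and a straight pentyl chain, a cyclopentyl ring or a benzyl group there would help to separate them. Also open, going by these compounds, is whether a ring-bearing group would act here as in a 7.4-fold lower number from compound 2 to compound 3 (0.87 log units; beyond the scatter), a step that lies on a different core.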